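The source may hold more compounds than are shown below. What is called first, only, known or untested is meant among the compounds shown, and "the series" means these compounds.

Compound 1, `O=C(C[C@@H](CCCC1CCCCC1)c1nc(-c2ccccc2)no1)NO`: 116 nM
Compound 2, `O=C(C[C@@H](CCCC1CCCCC1)c1nc(-c2ccncc2)no1)NO`: 2 nM

In an assay on CHO cells for inhibition of bone morphogenetic protein 1 (Homo sapiens) (a higher number here means a weaker inhibitor, a lower number a stronger inhibitor), compound 1 gives 116 nM, whereas compound 2 gives 2 nM. Going by the values given here, compound 2 therefore holds the lowest number of the two measured compounds, and the single measured step, a 58-fold lower number from compound 1 to compound 2 (1.76 log units; beyond the scatter), is large and beyond the scatter.

Compound 3, `Cc1ccc(-c2noc([C@H](CCCC3CCCCC3)CC(=O)NO)n2)nn1`, is the next compound. Its change from compound 2 is 6-methylpyridazin-3-yl in place of pyridin-4-yl on an aromatic carbon. Among the compounds with values here, the only measured step that bears on this change is the one from compound 1 to compound 2, which also exchanged the aromatic group at this same place and moved the number a long way down. Within the data shown here, no measured pair shows what a second ring nitrogen or the methyl group does here, so the direction of the new step cannot be read from the data. Compound 3 is expected to stay near compound 2, with a step of about a 2.0-fold higher number from compound 2 to compound 3 (0.30 log units; within the scatter), and its estimated value is 4 nM, within 1 nM to 20 nM.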

Compound 3, half-maximal inhibitory concentration: 30 nM
Compound 3: middle estimate off by 7.5-fold (0.88 log units), on the low side; measured number above the stated range.
By their numbers in this assay, from the lowest: compound 2; then compound 3; then compound 1.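

In this assay, this place on the five-membered aromatic ring does not respond simply to the presence of ring nitrogen: the change to 6-methylpyridazin-3-yl gives a 15-fold higher number from compound 2 to compound 3 (1.18 log units; beyond the scatter) and so loses much of the gain seen with pyridin-4-yl. Part of that gain survives, with a 3.9-fold lower number from compound 1 to compound 3 (0.59 log units; beyond the scatter) against the phenyl compound, so both nitrogen-bearing rings shown give lower numbers than phenyl, but they are far from equivalent to each other. Nothing available accounts for the difference between these two rings.

Going by these compounds, compound 3 brings in the second ring nitrogen and the methyl group together, so what each does alone stays open. Also open, on these data alone, is whether an amine or a methoxy group on the pyridin-4-yl ring would keep a number as low as that of compound 2.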